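A few compounds are considered here, and "the series" means these few. Any claim that something is new, unique, unknown or untested is made for them only; others in the source may bear on it.

In an ADME assay on ECV-304 cells (Homo sapiens) for cytotoxicity, read by MTT assay, with a stated time of 72 h (a lower number here means a stronger inhibitor, a higher number a weaker inhibitor), three compounds sharing a core have been tested. Compound 1 `COc1ccc(C2=C(c3cc(OC)c(OC)c(OC)c3)CC(O)C2=O)cc1[N+](=O)[O-]` gives > 100 ug/mL, a limit of the assay and not a number. Compound 2 `COc1cc(C2=C(c3cc(C)c(OC)c(C)c3)C(OC(C)=O)CC2=O)cc(OC)c1OC` gives > 100 ug/mL, again a limit. Compound 3 `COC(=O)c1cc(C2=C(c3cc(OC)c(OC)c(OC)c3)C(=O)CC2O[SiH2]C(C)(C)C)ccc1OC` gives > 100 ug/mL, also a limit, so it stands with the other two at the limit of > 100 ug/mL in this assay, at which 3 of the 3 values shown sit. Compound 4 `COCOc1cc(C2=C(c3cc(OC)c(OC)c(OC)c3)C(=O)CC2O[SiH2]C(C)(C)C)ccc1OC` has methoxymethoxy in place of methoxycarbonyl on an aromatic carbon, ortho to a methoxy group: methoxymethoxy in place of methoxycarbonyl on an aromatic carbon. Among the measured compounds shown here, no measured pair shows the effect of such a change, so no step beyond the scatter is expected in this assay. The expected step is a number no higher from compound 3 to compound 4 (the limit leaves the size open). Compound 4 is estimated at 100 ug/mL, within an expected range from 50 ug/mL to 150 ug/mL.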

Compound 4, half-maximal inhibitory concentration: 40 ug/mL
Beside the measured number, compound 4's estimate is 2.5-fold (0.40 log units) above it; measured number below the stated range.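

In this assay, methoxymethoxy in place of methoxycarbonyl on this aromatic carbon, ortho to a methoxy group, gives an at least 2.5-fold lower number from compound 3 to compound 4 (0.39 log units; beyond the scatter), so this position can influence the read-out. The two groups have the same heavy-atom and hydrogen-bond counts, so those counts alone do not separate them. Compound 4 is the only compound shown with a number rather than a limit: the limit of > 100 ug/mL in this assay, at which 3 of the 4 values shown sit.

From the compounds shown here alone, whether a hydroxyl group, an amine or a carboxylic acid on this carbon would lower the number further remains open. So does whether this change would have the same effect on the other compounds.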